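Turning the drawn stereocentre from R to S

The source may hold more compounds than are shown below. What is called first, only, known or untested is meant among the compounds shown, and "the series" means these compounds.

Compound 2 `C[C@@H](Nc1nc(C(=O)N2CCCC2)c2sccc2n1)c1cccnc1` stands highest of the two numbers shown in a functional assay on CHO-K1 cells for antagonist activity at adenosine receptor A2b (Homo sapiens), read by FLIPR and calcium flux (on this read-out lower numbers stand for stronger inhibition and higher numbers for weaker inhibition), with compound 2 giving 3070 nM. Its nearest neighbour is compound 1 `CC(Nc1nc(C(=O)N2CCCC2)c2sccc2n1)c1cccnc1`, drawn without a configuration at the saturated chain carbon; in this assay compound 1 gives 13 nM. For the measured compounds named here, the single measured step runs a 240-fold higher number from compound 1 to compound 2 (2.37 log units; beyond the scatter), and what bears on it is the fact that one of compounds 1 and 2 is drawn with a defined configuration and the other without, at the place where they differ: the two compounds share every atom and bond and differ only in whether the stereocentre is drawn with a configuration.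

Compound 3 `C[C@H](Nc1nc(C(=O)N2CCCC2)c2sccc2n1)c1cccnc1` differs from compound 2 by the two compounds have the same atoms and bonds and differ only in configuration as drawn: 1 of 1 stereo elements differ; a stereocentre at a saturated chain carbon is drawn R in compound 2 and S in compound 3. If the undefined drawing of compound 1 stands for both configurations, its number should lie between those of the two configured forms, so the S form would have to carry the activity that compound 2 lacks. Compound 3 is therefore expected to show a large step downward, a 440-fold lower number from compound 2 to compound 3 (2.64 log units; beyond the scatter), in this assay. The estimate for compound 3 is 7 nM, within a range from 2.5 nM to 20 nM.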

Compound 3, half-maximal inhibitory concentration: 18 nM
Compound 3: the middle estimate sits 2.6-fold (0.41 log units) below what was measured; the range from low to high includes it.
By their numbers in this assay, from the lowest: compounds 1 and 3 (each within the scatter of the next); then compound 2.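

With the two configurations now standing directly against each other in this assay, the step at this saturated chain carbon is a 170-fold lower number from compound 2 to compound 3 (2.23 log units; beyond the scatter), and nothing else in the structures changes: the fact that compounds 2 and 3 differ only in the configuration as drawn. The earlier step set the R form only against a drawing without a configuration, whereas the S form and that undefined drawing cannot be told apart, at a 1.4-fold higher number from compound 1 to compound 3 (0.14 log units; within the scatter): the fact that one of compounds 1 and 3 is drawn with a defined configuration and the other without, at the place where they differ. Among these three compounds, compound 2 alone stands apart, and the S form, compound 3, matches the low number of compound 1, so the configuration at this one carbon separates strong from weak inhibition in this series.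

On these data alone, what remains open is whether a gap of this size between the two configurations would survive if a longer chain or an amine were carried on this same carbon. The compounds shown also say nothing about why the R form stands so far from the S form, as they establish the size of the difference but not its origin.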